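This account rests on a few compounds, and the source may have more. Where it says the series, first, only, none or still open, it means among the compounds named here.

Two compounds in this series share one core and carry a sulfonyl-linked aryl group on it. Compound 1, `CN1CCC(n2cc(S(=O)(=O)c3cccc4ccccc34)c3ccccc32)C1`, bears a naphthyl group at that position, and compound 2, `CN1CCC(n2cc(S(=O)(=O)c3cccc(F)c3)c3cc(F)ccc32)C1`, carries a fluorinated phenyl group instead, with a second fluoro on the fused ring of the core. In an assay on HeLa cells for displacement of a labelled ligand from 5-hydroxytryptamine receptor 6 (Homo sapiens), with a stated time of 2 h (on this read-out lower numbers stand for stronger inhibition and higher numbers for weaker inhibition), compound 1 gives 6 nM, and in this assay compound 2 gives 5 nM. Compound 2 thus shows the lower of the two numbers, yet its gap to compound 1 lies within the scatter of repeated measurements, so the two compounds cannot be told apart on these data.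

Compound 3, `CN1CCC(n2cc(S(=O)(=O)c3cccc(F)c3)c3ccccc32)C1`, differs from compound 2 in a single place: hydrogen in place of fluoro on an aromatic carbon. Within the data shown here, there is no measured pair showing this change, so the expected step from compound 2 to compound 3 in this assay rests only on the smallness of the change, and the step of a 1.4-fold higher number from compound 2 to compound 3 (0.15 log units; within the scatter) is expected to stay within the scatter. Compound 3 is therefore estimated to give 7 nM, with a plausible range from 2.5 nM to 20 nM.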

Compound 3, inhibition constant: 3.5 nM
Estimate against measurement, compound 3: 2.0-fold (0.30 log units) above; measured number inside the range.
By their numbers in this assay, from the lowest: compounds 3, 2 and 1 (each within the scatter of the next).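

In this assay, among these compounds, the first pair that differs in one place gives a 1.4-fold lower number from compound 2 to compound 3 (0.15 log units; within the scatter) for hydrogen in place of fluoro on this aromatic carbon of the fused system. The fluoro is therefore not required for a number of this size here: with hydrogen on that carbon the compound stays in the same low range, and compound 2 and compound 3 cannot be told apart on these data. Among the compounds shown here, no other measurement bears on this result, so the pair shows only that this one exchange leaves the binding read-out within the scatter.

Only fluoro and hydrogen are shown on this carbon, so it remains open whether a larger or differently built group, such as methoxy, an amine or a carboxylic acid, would leave the number as little moved as this exchange did. For the compounds shown here, the single pair also says nothing about the fluoro on the sulfonyl-linked phenyl group, where hydrogen or a nitrile could give a different result.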